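Halogen in place of trifluoromethyl on the shared core

The compounds below may be only part of what the source reports. "The series", "measured", "known", "first", "only" and "open" are said of these compounds alone.

Compound 1, `O=C(Nc1ccc(-n2ncc3c(C(F)(F)F)cccc32)cc1)Nc1ccc(Cl)c(C(F)(F)F)c1`: compound 1 gives 1600 nM in a functional assay on NCI-H460 cells (Homo sapiens) for cytotoxicity, read by MTT assay, with a stated time of 72 h; on this read-out lower numbers stand for stronger inhibition and higher numbers for weaker inhibition
Compound 2, `O=C(Nc1ccc(-n2ncc3c(Cl)cccc32)cc1)Nc1ccc(Cl)c(C(F)(F)F)c1`: compound 2 gives 1300 nM in this assay

Going by the values given here, of the two numbers measured so far in this assay, compound 1 stands highest, and its nearest neighbour is compound 2, which sits a 1.2-fold lower number from compound 1 to compound 2 (0.09 log units; within the scatter). Among the compounds with values here, that single step, a chloro in place of a trifluoromethyl on an aromatic carbon of the shared core, is also the only measured step that bears on the change now in question.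

Compound 3, `O=C(Nc1ccc(-n2ncc3c(Br)cccc32)cc1)Nc1ccc(Cl)c(C(F)(F)F)c1`, differs from compound 1 in one place: bromo in place of trifluoromethyl on an aromatic carbon. A bromo thus takes the position where compound 2 carries a chloro, on an aromatic carbon of a six-membered aromatic ring of carbon only, part of a fused system of two rings.

Since the step from compound 1 to compound 2 stayed within the scatter, the corresponding exchange for bromo is expected to give no step beyond the scatter either, perhaps a slightly lower number, a 1.3-fold lower number from compound 1 to compound 3 (0.12 log units; within the scatter). The estimate for compound 3 in this assay is therefore 1200 nM, with a range from 600 nM to 2400 nM.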

Compound 3, half-maximal inhibitory concentration: 1300 nM
Estimate against measurement, compound 3: 1.1-fold (0.03 log units) below; low and high end bracket the measured number.
By their numbers in this assay, from the lowest: compounds 2, 3 and 1 (each within the scatter of the next).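

With bromo in place of trifluoromethyl on this aromatic carbon, this assay shows a 1.2-fold lower number from compound 1 to compound 3 (0.09 log units; within the scatter), so a second halogen now joins chloro in giving a step that stays inside the scatter. Going by these compounds alone, the direct comparison of the two halogens, which the earlier compounds could not offer, gives no change at the digits printed from compound 2 to compound 3 (within the scatter), so chloro and bromo cannot be told apart at this position, and trifluoromethyl, chloro and bromo all read alike here within the scatter. Nothing measured on these compounds speaks to why the three groups read alike.

As far as these compounds go, whether the same holds beyond these three groups stays open, since an amine, a hydroxyl, a methoxy group or a carboxylic acid on the same aromatic carbon might give quite a different number. From the compounds shown here alone, all three compounds also share the rest of their structure and are read in these cells alone, so it remains open whether this insensitivity at the position would persist with the remainder of the shared core changed or in another cell line.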